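The compounds below may be only part of what the source reports. "The series", "measured", "known", "first", "only" and "open" are said of these compounds alone.

In a functional assay on KB cells (Homo sapiens) for inhibition (on this read-out lower numbers stand for stronger inhibition and higher numbers for weaker inhibition), compound 1 `Nc1nc2cc(Cl)c(Cl)cc2n1Cc1cccc(Cl)c1` gives 65000 nM and stands level with compound 2 `Cc1cccc(Cn2c(N)nc3cc(Cl)c(Cl)cc32)c1`, which gives 65000 nM. Next is compound 3 `Clc1cccc(Cn2c(Br)nc3cc(Cl)c(Cl)cc32)c1`, reached by the change bromo in place of amino on an aromatic carbon, between two ring nitrogen atoms. Among the compounds with values here, the only measured step is no change at the digits printed from compound 1 to compound 2 (within the scatter), methyl in place of chloro on an aromatic carbon. That step lies within the scatter, but it concerns another part of the molecule and says little about this place. Within the data shown here, no measured step touches the amino group, so the data give no direction. No shift beyond the scatter is therefore expected in this assay, with wide uncertainty. The expected step is a 1.1-fold lower number from compound 1 to compound 3 (0.03 log units; within the scatter). For compound 3 the estimated value is 60000 nM, with an expected range of 20000 nM to 150000 nM.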

Compound 3, half-maximal inhibitory concentration: > 100000 nM
Compound 3: only a limit was reported (the forecaster's own chance of this, stated with the estimate: 15%); middle value at least 1.6-fold (0.22 log units) from the limit.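

Within the data shown here, compound 3 gives the only reading that touches the place between two ring nitrogen atoms, where bromo stands in place of amino. In this assay the step reads as an at least 1.5-fold higher number from compound 1 to compound 3 (0.18 log units; that floor lies within the scatter). Compound 3 gives > 100000 nM, which is a limit of the assay and not a number. The step therefore has only a floor, so this change cannot be called a real weakening, and its true size stays unknown: the limit of > 100000 nM in this assay, at which 1 of the 3 values shown sits.

Open, going by these compounds, is how other groups at this place would read, for example methylamino, dimethylamino or hydroxyl, and whether any of them would give a number rather than a limit. Also open, on these data alone, is whether bromo in place of amino would read the same on compound 2, which carries methyl in place of chloro on an aromatic carbon.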